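The source may hold more compounds than are shown below. What is called first, only, known or untested is meant among the compounds shown, and "the series" means these compounds.

Compound 1 `CN(C)CCn1c(N)c(-c2nc3ccccc3[nH]2)c2nc(C#N)c(C#N)nc21`: > 50000 nM (a limit)
Compound 2 `CCN(CC)CCn1c(N)c(-c2nc3ccccc3[nH]2)c2nc(C#N)c(C#N)nc21`: > 50000 nM (a limit)
Compound 3 `CN(C)CCn1c(N)c(-c2nc3ccccc3s2)c2nc(C#N)c(C#N)nc21`: > 50000 nM (a limit)

In a functional assay on A549 cells (Homo sapiens) for antiproliferative activity, read by MTT assay, with a stated time of 48 h (a higher number here means a weaker inhibitor, a lower number a stronger inhibitor), compound 3 gives > 50000 nM, which is a limit of the assay and not a number. It has company, since the whole set rests at one ceiling: the limit of > 50000 nM in this assay, at which 3 of the 3 values shown sit.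

Compound 4 `CN(C)CCCCn1c(N)c(-c2nc3ccccc3s2)c2nc(C#N)c(C#N)nc21` shares the core of compound 3 and its 1,3-benzothiazol-2-yl group. The change lies in the chain, with 2-(dimethylamino)ethyl in place of dimethylamino on a saturated chain carbon, two bonds along the chain from an aromatic nitrogen. Cut one bond further out, this reads 2-(dimethylamino)ethyl to 4-(dimethylamino)butyl.

Two measured steps come closest, and neither gives a size. One alters the amine end of the chain: a step that the two limits leave unreadable from compound 1 to compound 2. The other leads to the core and group that compound 4 keeps: a step that the two limits leave unreadable from compound 1 to compound 3. Among the compounds with values here, no measured step alters the chain length itself, so the data point to no direction, and no step beyond the scatter is expected in this assay.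

The expectation rests on compound 3, whose value > 50000 nM is a limit. The expected change is a number no higher from compound 3 to compound 4 (the limit leaves the size open). For compound 4 the estimate is 50000 nM, with an expected range of 15000 nM to 100000 nM.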

Compound 4, half-maximal inhibitory concentration: 35800 nM
Estimate against measurement, compound 4: 1.4-fold (0.15 log units) above, and the stated range covers the measured number.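

Within the data shown here, compound 4 is the first compound here in this assay to give a number and not a limit, 35800 nM, so 4-(dimethylamino)butyl in place of 2-(dimethylamino)ethyl yields the first numerical reading on this chain. The change at this place, on a saturated chain carbon, two bonds along the chain from an aromatic nitrogen, gives an at least 1.3-fold lower number from compound 3 to compound 4 (0.14 log units; that floor lies within the scatter), which fixes only a floor and leaves the true size of the step open. Compound 3, the partner in this comparison, has a limit of the assay as its value, and it shares that limit with the other earlier compounds: the limit of > 50000 nM in this assay, at which 3 of the 4 values shown sit.

How the number moves with chain length remains open, since neither 3-(dimethylamino)propyl nor a longer chain such as 6-(dimethylamino)hexyl is among the compounds shown. Also open, going by these compounds, is what happens when the 4-(dimethylamino)butyl chain carries a diethylamino end, a ring amine such as morpholine, or sits on the compound with 1H-benzimidazol-2-yl in place of 1,3-benzothiazol-2-yl.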